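Replacing Pyridin-2-yl with 3-Methylphenyl on Compound 2

A few compounds are considered here, and "the series" means these few. Any claim that something is new, unique, unknown or untested is made for them only; others in the source may bear on it.

Of the compounds shown here, two of this set have been measured in an assay on CHO cells for displacement of a labelled ligand from adenosine receptor A1 (Homo sapiens), read by scintillation counting, tested at 10 uM; a higher number here means more inhibition at the concentration tested (going by the name of the read-out), a lower number less inhibition. Compound 1 `CC(C)(C)Cc1csc(N)c1C(=O)c1cccc(Cl)c1` gives 2% in this assay. Going by the values given here, compound 2 `CC(C)(C)Cc1c(-c2ccccn2)sc(N)c1C(=O)c1ccc(Cl)cc1` gives 1% in this assay, and that number and the one for compound 1 lie within the usual scatter of each other, so the two cannot be told apart. Among the compounds with values here, both sit close to zero, meaning that at the single concentration tested neither compound displaces much of the labelled ligand.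

Compound 3 `Cc1cccc(-c2sc(N)c(C(=O)c3ccc(Cl)cc3)c2CC(C)(C)C)c1` has not yet been measured. It differs from compound 2 in one place: 3-methylphenyl in place of pyridin-2-yl on an aromatic carbon. Within the data shown here, no step between two measured compounds shows what such a swap does here. With both measured numbers near zero, the expected step of a number 2 percentage points higher from compound 2 to compound 3 (within the scatter) is none beyond the scatter. Compound 3 is therefore estimated at 3%, with a range from -8% to 15%.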

Compound 3, a percentage reported as inhibition, at one concentration (the size of the read-out at that concentration, not a potency): 1%
Estimate against measurement, compound 3: 2 percentage points above; low and high end bracket the measured number.
By their numbers in this assay, from the lowest: compounds 2, 3 and 1 (each within the scatter of the next).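

In this assay, going by these compounds alone, putting 3-methylphenyl in place of pyridin-2-yl on the aromatic carbon next to the ring sulfur gives no change at the digits printed from compound 2 to compound 3 (within the scatter) and so provides the first direct reading of a change at this position. Exchanging this ring, which carries a nitrogen and a hydrogen-bond acceptor, for a ring of carbon only leaves the number near zero at the single concentration tested. No measurement shown here bears on why this is so.

From the compounds shown here alone, whether an amine or a carboxylic acid on this aromatic ring, or a longer chain in its place, would give a number beyond the scatter remains open. Also open, going by these compounds, is whether compound 2 and compound 3 would differ at a higher concentration, where more displacement might appear.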